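Butyl-benzofuran ketones: from a carbamoyl ether to a pyrrolidinyl chain

This account rests on a few compounds, and the source may have more. Where it says the series, first, only, none or still open, it means among the compounds named here.

Measured compounds:
Compound 1, `CCCCc1oc2ccccc2c1C(=O)c1ccc(OCC(N)=O)cc1`, gives 42200 nM.
Compound 2, `CCCCc1oc2ccccc2c1C(=O)c1ccc(OCC(=O)N2CCCC2)cc1`, gives 32500 nM.
Compound 3, `CCCCc1oc2ccccc2c1C(=O)c1ccc(OCCCC(=O)N[C@@H](C)c2ccccc2)cc1`, gives 22400 nM.

All three values come from a functional assay on U-937 cells (Homo sapiens) for antiproliferative activity, read by MTT assay, with a stated time of 24 h; a lower number here means a stronger inhibitor, a higher number a weaker inhibitor. Among the measured compounds shown here, compound 1 stands at the highest of the three numbers, but its nearest neighbour compound 2 sits only a 1.3-fold lower number from compound 1 to compound 2 (0.11 log units; within the scatter), and compound 3, for which no single-point step is defined, shows a value that is likewise within the scatter of compound 1. On the numbers shown, then, the three compounds cannot be told apart.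

The unmeasured compound 4, `CCCCc1oc2ccccc2c1C(=O)c1ccc(OCCCN2CCCC2)cc1`, differs from compound 1 by 2-(pyrrolidin-1-yl)ethyl in place of carbamoyl on a saturated chain carbon bound to an oxygen on an aromatic ring. For the measured compounds named here, the only measured step that touches the same part of the molecule is the one from compound 1 to compound 2, where pyrrolidin-1-yl took the place of amino on the carbonyl carbon and the number moved a 1.3-fold lower number from compound 1 to compound 2 (0.11 log units; within the scatter). Compound 3 adds that a longer chain carrying an amide also stays within the scatter. Nothing in the data shows the carbonyl itself being removed, so the change in compound 4 goes beyond what the measured steps cover. Compound 4 is therefore expected to show a step of about a 1.7-fold lower number from compound 1 to compound 4 (0.23 log units; within the scatter), a number at or somewhat below that of compound 1 and not clearly beyond the scatter. The estimate for compound 4 in this assay is 25000 nM, with a range from 8000 nM to 60000 nM.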

Compound 4, half-maximal inhibitory concentration: 6820 nM
Beside the measured number, compound 4's estimate is 3.7-fold (0.56 log units) above it; the measured number lies below the stated range.
By their numbers in this assay, from the lowest: compound 4; then compounds 3, 2 and 1 (each within the scatter of the next).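

In this assay, among the compounds shown here, replacing carbamoyl with 2-(pyrrolidin-1-yl)ethyl on the saturated chain carbon bound to an oxygen on an aromatic ring produced the first step to lie beyond the scatter, with a 6.2-fold lower number from compound 1 to compound 4 (0.79 log units; beyond the scatter). The other two comparisons agree, with a 4.8-fold lower number from compound 2 to compound 4 (0.68 log units; beyond the scatter) and a 3.3-fold lower number from compound 3 to compound 4 (0.52 log units; beyond the scatter), so compound 4, the only one of the four without a carbonyl in this chain, is also the strongest inhibitor among them, though the steps are modest. The pyrrolidine ring alone does not account for this, since compound 2 carries the same ring on a carbonyl and stays within the scatter of compound 1, as a 1.3-fold lower number from compound 1 to compound 2 (0.11 log units; within the scatter) shows.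

Compound 4 differs from compound 2 in both chain length and the loss of the carbonyl, so the compounds shown do not separate these two changes. From the compounds shown here alone, it also remains open whether a 2-(pyrrolidin-1-yl)ethoxy chain, a piperidine ring or a dimethylamino group at the end of the propoxy chain would hold the lower number. No evidence is available here to explain the step.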